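The source may hold more compounds than are shown below. What is called first, only, known or untested is meant among the compounds shown, and "the series" means these compounds.

Measured so far in a functional assay on HL-60 cells (Homo sapiens) for inhibition, read by MTT assay, with a stated time of 72 h, tested at 50 uM; a higher number here means more inhibition of growth at the concentration tested, a lower number less inhibition of growth:
- Compound 1 `C=CCc1ccc(OCc2cn(-c3ccc(C#N)cc3)nn2)c(O)c1`: 31.8%
- Compound 2 `C=CCc1ccc(OCc2cn(-c3ccccc3Cl)nn2)c(O)c1`: 43.2%
- Compound 3 `C=CCc1ccc(OCc2cn(-c3ccc(OC)cc3)nn2)c(O)c1`: 38.9%

Compound 3 cannot be told apart from either of the other two. The data show a number 7.1 percentage points higher from compound 1 to compound 3 (within the scatter) and a number 4.3 percentage points lower from compound 2 to compound 3 (within the scatter). Only one step among these compounds clears the scatter: a number 11.4 percentage points higher from compound 1 to compound 2 (beyond the scatter).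

The unmeasured compound 4 `C=CCc1ccc(OCc2cn(-c3ccccc3CO)nn2)c(O)c1` keeps the shared core and changes one group: 2-(hydroxymethyl)phenyl in place of 4-methoxyphenyl on an aromatic nitrogen. The two compounds have the same atoms, joined differently.

All three measured steps swap the group on this same aromatic nitrogen, so they are the best guide available. The largest of them is still modest, and two stay within the scatter. For the measured compounds named here, no measured compound carries a hydroxymethyl group, so the data offer no direct comparison for it. In this assay, a step of similar or smaller size is therefore expected, with no clear direction. The expected change is a number 0.9 percentage points lower from compound 3 to compound 4 (within the scatter), which would not lie beyond the scatter. Compound 4 is estimated at 38%, with an expected range of 26% to 50%.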

Compound 4, percent growth inhibition at one concentration: 47.1%
For compound 4 the middle estimate is 9.1 percentage points below the measured one; the range from low to high includes it.
By their numbers in this assay, from the lowest: compounds 1, 3, 2 and 4 (each within the scatter of the next, the first and the last beyond it).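

In this assay, 2-(hydroxymethyl)phenyl brings a hydrogen-bond donor to this aromatic nitrogen, unlike 4-methoxyphenyl, yet the data show a number 8.2 percentage points higher from compound 3 to compound 4 (within the scatter) and a number 3.9 percentage points higher from compound 2 to compound 4 (within the scatter), so the new group cannot be told apart from either earlier group. Against 4-cyanophenyl the data show a number 15.3 percentage points higher from compound 1 to compound 4 (beyond the scatter), which makes this the second step to clear the scatter, and both such steps start from compound 1. No measurement here explains these steps.

Going by these compounds, whether an aminomethyl group, a carboxylic acid or a longer chain ending in a hydroxyl, in place of hydroxymethyl, would clear the scatter against compound 4 remains open. These readings also come from a single concentration, so they leave open how the compounds would compare across a range of concentrations.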